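The compounds below may be only part of what the source reports. "The series", "measured", "known", "first", "only" and "open" are said of these compounds alone.

In a functional assay on NCI-H23 cells (Homo sapiens) for inhibition (on this read-out higher numbers stand for weaker inhibition of growth and lower numbers for stronger inhibition of growth), compound 1 (`COc1cc(/C=C/c2ccc(S(N)(=O)=O)cc2)cc(OC)c1`) gives 22500 nM and compound 2 (`COc1cccc(/C=C/c2ccc(S(N)(=O)=O)cc2)c1`) gives 21000 nM. Compound 3 (`NS(=O)(=O)c1ccc(/C=C/c2ccc(F)cc2)cc1`) gives 45100 nM, a number beyond the scatter above that of compound 2 but within the scatter of compound 1. Compound 4 (`CN(C)c1ccc(/C=C/c2ccc(S(N)(=O)=O)cc2)cc1`) has dimethylamino in place of fluoro on an aromatic carbon, para to a large group: dimethylamino in place of fluoro on an aromatic carbon. Within the data shown here, the only measured step is a 1.1-fold lower number from compound 1 to compound 2 (0.03 log units; within the scatter), hydrogen in place of methoxy. It involves neither fluoro nor dimethylamino, so it offers only weak guidance, and no change beyond the scatter is expected in this assay. The expected size is a 1.5-fold lower number from compound 3 to compound 4 (0.18 log units; within the scatter). For compound 4 the estimated number is 30000 nM, with an expected range of 9000 nM to 75000 nM.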

Compound 4, concentration for 50% growth inhibition: 14200 nM
Compound 4: middle estimate off by 2.1-fold (0.32 log units), on the high side; the measured number falls inside the stated range.
By their numbers in this assay, from the lowest: compounds 4, 2, 1 and 3 (each within the scatter of the next, the first and the last beyond it).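

In this assay, dimethylamino in place of fluoro on an aromatic carbon, para to a large group, gives a 3.2-fold lower number from compound 3 to compound 4 (0.50 log units; beyond the scatter), so inhibition of growth is stronger with dimethylamino at this position. This is the only single change shown that goes beyond the scatter, whereas the change from methoxy to hydrogen gives just a 1.1-fold lower number from compound 1 to compound 2 (0.03 log units; within the scatter). Nothing measured here accounts for the difference.

From the compounds shown here alone, it remains open whether the gain depends on the nitrogen or on its two methyl groups. A primary amine or a carboxylic acid at this position would test how far it extends.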